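The compounds below may be only part of what the source reports. "The series", "measured", "known", "first", "only" and "open" are said of these compounds alone.

Three compounds carrying the same core were tested in an assay on cell membranes for displacement of a labelled ligand from metabotropic glutamate receptor 5 (Rattus norvegicus), tested at 1 uM; on this read-out lower numbers stand for less inhibition and higher numbers for more inhibition at the one concentration tested (going by the name of the read-out). Compound 1, `Fc1ccc(-c2nnc(-c3sc4ncccc4c3-c3ccc(Cl)cc3)o2)cc1`, gives 24% in this assay. Compound 2, `CN(C(=O)c1sc2ncccc2c1-c1ccc(F)cc1)c1ccc(F)cc1`, gives 19% in this assay. Compound 3, `O=C(Oc1ccc(F)cc1)c1sc2ncccc2c1-c1ccc(Cl)cc1`, gives 15% in this assay. The three numbers lie within the usual scatter of one another, so none of the three compounds can be set apart from the others on this read-out, and all three sit at a modest level of inhibition.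

Compound 4, `O=C(Nc1ccc(F)cc1)c1sc2ncccc2c1-c1ccc(Cl)cc1`, has not yet been measured in this assay. It differs from compound 3 in one place: (4-fluorophenyl)amino in place of 4-fluorophenoxy on a carbonyl carbon. Going by the values given here, no pair of measured compounds shows what this exchange does on the core, so the size of the step cannot be read from the numbers at hand; what is known is that the measured values for the three carbonyl-bearing analogues cluster close together.

The account therefore expects the step from compound 3 to compound 4 in this assay, a number 5 percentage points higher from compound 3 to compound 4 (within the scatter), to be small and of no clear direction beyond the scatter. Compound 4 is accordingly estimated to give 20% in this assay, within a range from 5% to 40%.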

Compound 4, a percentage reported as inhibition, at one concentration (the size of the read-out at that concentration, not a potency): 0%
Compound 4: middle estimate off by 20 percentage points, on the high side; measured number outside the range, below it.
By their numbers in this assay, from the lowest: compound 4; then compounds 3, 2 and 1 (each within the scatter of the next).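

In this assay, going by these compounds alone, the exchange of 4-fluorophenoxy for (4-fluorophenyl)amino on a carbonyl carbon gives the first step on the shared core that can be read, a number 15 percentage points lower from compound 3 to compound 4 (beyond the scatter), and this step lies beyond the scatter. The earlier compounds shown here sat within the scatter of one another and gave no sign that anything at this place mattered, whereas this pair shows that the read-out responds to a change here, with less inhibition for the amide-type compound 4. The two groups have the same number of heavy atoms and the same aromatic ring, and differ in oxygen against nitrogen and in their hydrogen-bond donors and acceptors, but nothing shown ties the step to any one of these differences.

The compounds shown leave open whether the same exchange would have a similar effect with other groups on the shared core, since this is the only pair that isolates it. They also leave open what a carboxylic acid, a benzylamino group or a longer chain on the same carbonyl carbon would give on this read-out, and whether any group at this place could raise inhibition beyond the modest level seen so far.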